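This account rests on a few compounds, and the source may have more. Where it says the series, first, only, none or still open, it means among the compounds named here.

In a functional assay on DU-145 cells (Homo sapiens) for antiproliferative activity, read by sulforhodamine B assay, with a stated time of 3 days (on this read-out lower numbers stand for stronger inhibition of growth and higher numbers for weaker inhibition of growth), compound 1 `O=C(c1cccc(Nc2ncc(F)c(Nc3ccc(F)cc3)n2)c1)N1CCCCC1` gives 13000 nM. Compound 2 `O=C(Nc1cccc(Nc2ncc(F)c(Nc3ccc(F)cc3)n2)c1)c1ccccc1` is known only as a limit, > 10000 nM. For the measured compounds named here, the series so far shows (the limit of > 10000 nM in this assay, at which 1 of the 2 values shown sits). Compound 3 `O=C(NCCO)c1cccc(Nc2ncc(F)c(Nc3ccc(F)cc3)n2)c1` is the next to consider. It has (2-hydroxyethyl)carbamoyl in place of benzamido on an aromatic carbon, meta to a large group, and the change counts as follows: (2-hydroxyethyl)carbamoyl in place of benzamido on an aromatic carbon.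

Going by the values given here, only one measured step bears on this change, and it gives no size to work from. It is a step that the limit leaves unreadable from compound 1 to compound 2, with benzamido in place of (piperidin-1-yl)carbonyl at the same place. Among the compounds with values here, the only firm number nearby is that of compound 1, at 13000 nM, so the expectation rests mainly on that value. No step beyond the usual scatter is expected in this assay, and neither direction is favoured. The expected step is a number no higher from compound 2 to compound 3 (the limit leaves the size open). For compound 3 the estimated value is 10000 nM, with an expected range from 3000 nM to 30000 nM.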

Compound 3, concentration for 50% growth inhibition: 13400 nM
The estimate for compound 3 lay 1.3-fold (0.13 log units) below the measured number; the range from low to high includes it.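

In this assay, for the compounds shown here, the change from compound 1 to compound 3 gives the first readable step at this position: exchanging piperidin-1-yl for (2-hydroxyethyl)amino on the carbonyl carbon is a 1.0-fold higher number from compound 1 to compound 3 (0.01 log units; within the scatter). Going by these compounds alone, the earlier compounds could not show this, as they offered only one firm number. Compound 3 adds a second, and a closed ring and an open chain carrying a hydroxyl group on the same carbonyl carbon cannot be told apart in this read-out. Compound 2 remains a limit rather than a number, so the steps that touch it cannot be read, and whether benzamido differs from either of the other two groups stays unknown: the limit of > 10000 nM in this assay, at which 1 of the 3 values shown sits.

With only these two readable amides, the compounds shown leave open whether any group at this position can move the number beyond the scatter in either direction. A carboxylic acid in place of the carbonyl-linked amine, or a longer chain ending in a dimethylamino group, would test this, and the present values say nothing about how either would behave.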